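A Second Methoxy on the Aryl Ring of Compound 2

The source may report more compounds than this note shows. Statements on the series, on what has been measured and on what is new or still open speak of the compounds shown alone.

Three compounds have been measured in an assay on isolated protein for inhibition of beta-glucuronidase (Bos taurus), read by spectrophotometry, with a stated time of 30 min; a higher number here means a weaker inhibitor, a lower number a stronger inhibitor:
Compound 1, `Cc1ccc(Nc2nnc(-c3ccccc3Cl)s2)cc1`, gives 16700 nM.
Compound 2, `COc1ccccc1-c1nnc(Nc2ccc(C)cc2)s1`, gives 58100 nM.
Compound 3, `COc1ccccc1-c1nnc(Nc2cccc(Br)c2)s1`, gives 49200 nM.

Compound 2 has the highest number of the three. Its gap to compound 3 is within the scatter, and only its gap to compound 1 is beyond it: a 3.5-fold higher number from compound 1 to compound 2 (0.54 log units; beyond the scatter). The step of a 1.2-fold lower number from compound 2 to compound 3 (0.07 log units; within the scatter), which swaps the group on the nitrogen, stays within the scatter.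

Compound 4, `COc1ccc(-c2nnc(Nc3ccc(C)cc3)s2)c(OC)c1`, differs from compound 2 by methoxy in place of hydrogen on an aromatic carbon, placed meta to the methoxy already present and para to a large group. For the measured compounds named here, no measured step adds a group to a ring that already carries one, so there is no direct precedent. Going by the values given here, the one change on this ring, from chloro to methoxy, gave a modest rise; the change on the other ring gave none. A step no larger than the scatter is therefore expected, in either direction, a 1.1-fold lower number from compound 2 to compound 4 (0.02 log units; within the scatter). Compound 4 is expected to give 55000 nM, within 20000 nM to 150000 nM.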

Compound 4, half-maximal inhibitory concentration: 39300 nM
For compound 4 the middle estimate is 1.4-fold (0.15 log units) above the measured one; measured number inside the range.
By their numbers in this assay, from the lowest: compound 1; then compounds 4, 3 and 2 (each within the scatter of the next).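

For the compounds shown here, this is the first measured case of a group added to a ring that already carries one. In this assay, methoxy in place of hydrogen, meta to the methoxy already present and para to a large group, gives a 1.5-fold lower number from compound 2 to compound 4 (0.17 log units; within the scatter). This position therefore takes a second methoxy, with its 2 heavy atoms, without a step beyond the scatter, although nothing measured here bears on why that is so.

The compounds shown leave open whether an amine, a carboxylic acid or a longer chain such as propoxy at this same position would give a step beyond the scatter. They also leave open whether a second methoxy would give a similar step with the 3-bromophenyl group of compound 3 on the nitrogen.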